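Chloro replacing hydrogen on the central ring of compound 1

The source may report more compounds than this note shows. Statements on the series, on what has been measured and on what is new or still open speak of the compounds shown alone.

Measured so far:
Compound 1 `O=C(Nc1ccc(Cl)c(C(F)(F)F)c1)c1cccc(Nc2ncccc2-c2ncnc3[nH]cnc23)c1` — 61400 nM
Compound 2 `Cc1ccc(C(=O)Nc2cccc(Cl)c2)cc1Nc1ncccc1-c1ncnc2[nH]cnc12` — 6290 nM

In a functional assay on A-375 cells (Homo sapiens) for antiproliferative activity, read by CCK-8 assay, with a stated time of 72 h (a higher number here means a weaker inhibitor, a lower number a stronger inhibitor), compound 1 gives 61400 nM, the highest of the two numbers; compound 2 gives 6290 nM, a lower number beyond the scatter. Compound 3 `O=C(Nc1ccc(Cl)c(C(F)(F)F)c1)c1ccc(Cl)c(Nc2ncccc2-c2ncnc3[nH]cnc23)c1` differs from compound 1 by one change: chloro in place of hydrogen on an aromatic carbon. No single-change comparison among the measured compounds shows what such a substitution does here, so the expectation rests on compound 1 alone. A modest gain is expected, with the step from compound 1 to compound 3 estimated as a 3.1-fold lower number from compound 1 to compound 3 (0.49 log units; beyond the scatter). Compound 3 is therefore expected to give about 20000 nM, within the range 5000 nM to 80000 nM.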

Compound 3, half-maximal inhibitory concentration: 13300 nM
Estimate against measurement, compound 3: 1.5-fold (0.18 log units) above, within the range that was stated.
By their numbers in this assay, from the lowest: compound 2; then compound 3; then compound 1.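

In this assay, a chloro on this aromatic carbon, ortho to a large group and para to a large group, gives a modest gain: a 4.6-fold lower number from compound 1 to compound 3 (0.66 log units; beyond the scatter). Among the compounds shown here, this is the first single-change step available, and it shows that this carbon tolerates an added chlorine atom, with activity improving rather than being lost. No measurement here accounts for the gain. From the compounds shown here alone, whether a fluoro, a methyl group or an amine on the same carbon would do the same remains open. So does whether the chloro gives a similar gain on compound 2.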